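Fluoro for trifluoromethyl in a small series

The compounds below may be only part of what the source reports. "The series", "measured", "known", "first", "only" and "open" are said of these compounds alone.

Compound 1 `CCCC(C)Oc1ccc(C(=O)/C=C/c2c(/C=C/c3ccc(OC)cc3)cc(OC)cc2OC)cc1` gives 11.1 ug/mL
Compound 2 `CCCCCCOc1ccc(C(=O)/C=C/c2c(/C=C/c3ccc(OC)cc3)cc(OC)cc2OC)cc1` gives 16.2 ug/mL
Compound 3 `COc1ccc(/C=C/c2cc(OC)cc(OC)c2/C=C/C(=O)c2ccc(C(F)(F)F)cc2)cc1` gives 18.7 ug/mL

These compounds share one core and differ in a single group. In a functional assay on HepG2 cells (Homo sapiens) for antiproliferative activity, read by MTT assay, with a stated time of 48 h (a higher number here means a weaker inhibitor, a lower number a stronger inhibitor), compound 3 gives 18.7 ug/mL and this number lies within the scatter of the values for both other compounds, so the three cannot be ranked.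

The next compound is compound 4 `COc1ccc(/C=C/c2cc(OC)cc(OC)c2/C=C/C(=O)c2ccc(F)cc2)cc1` which differs from compound 3 by fluoro in place of trifluoromethyl on an aromatic carbon with fluoro in place of trifluoromethyl on an aromatic carbon, para to a large group.

Among the compounds with values here, three measured steps concern this same place. Trifluoromethyl in place of 1-methylbutoxy gave a 1.7-fold higher number from compound 1 to compound 3 (0.23 log units; within the scatter) and trifluoromethyl in place of hexyloxy gave a 1.2-fold higher number from compound 2 to compound 3 (0.06 log units; within the scatter) while hexyl in place of 1-methylbutyl on the oxygen gave a 1.5-fold higher number from compound 1 to compound 2 (0.16 log units; within the scatter) as the third. None of these steps went beyond the scatter. Within the data shown here, no measured compound carries fluoro, so this expectation reaches past the data.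

The expected outcome is a 1.2-fold lower number from compound 3 to compound 4 (0.07 log units; within the scatter) and no step beyond the scatter is expected in this assay for this change. The estimated value for compound 4 is 16 ug/mL with an expected range from 8 ug/mL to 30 ug/mL as the span of likely results.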

Compound 4, half-maximal inhibitory concentration: 12.2 ug/mL
The estimate for compound 4 lay 1.3-fold (0.12 log units) above the measured number; low and high end bracket the measured number.
By their numbers in this assay, from the lowest: compounds 1, 4, 2 and 3 (each within the scatter of the next).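

In this assay the swap of trifluoromethyl for fluoro, a single fluorine atom in place of a group of four heavy atoms, gave a 1.5-fold lower number from compound 3 to compound 4 (0.19 log units; within the scatter) and so adds a fourth group at this position without a step beyond the scatter. Fluoro also compares directly with the two longer oxygen-linked groups, with a 1.3-fold lower number from compound 2 to compound 4 (0.12 log units; within the scatter) for hexyloxy and a 1.1-fold higher number from compound 1 to compound 4 (0.04 log units; within the scatter) for 1-methylbutoxy, so among these four compounds a lone fluorine atom cannot be told apart from either chain, and the numbers do not follow the size of the group. No measurement is available that could explain why the values stay so close together.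

The compounds shown leave open whether an amine, a carboxylic acid or a hydroxyl group on this aromatic carbon would move the number beyond the scatter of these four values. From the compounds shown here alone, it also remains open whether the same flat picture would hold in another cell line, or with a change elsewhere on the shared core.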